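Working notes: from compound 3 to compound 4

The source may report more compounds than this note shows. Statements on the series, on what has been measured and on what is new or still open speak of the compounds shown alone.

Compound 3 `[N-]=[N+]=NCCCCc1ccc(-c2ccc(-c3ccc(-c4cccs4)s3)s2)s1` has no number in an ADME assay on MDCK cells (Canis lupus familiaris) for cytotoxicity, read by MTT assay, with a stated time of 2 days; on this read-out higher numbers stand for lower toxicity in this test and lower numbers for higher toxicity in this test: its entry reads "not determined" (no result reported). Compound 1 `[N-]=[N+]=NCCCCc1ccc(-c2ccc(-c3ccc(-c4ccc(CCCCN=[N+]=[N-])s4)s3)s2)s1` likewise reads "not determined" (no result reported). Compound 2 `BrCCCCc1ccc(-c2ccc(-c3ccc(CCCCBr)s3)s2)s1` gives > 200000 nM, which is a limit of the assay and not a number. Compound 3 therefore holds no position of its own on this scale. Next comes compound 4 `BrCCCc1ccc(-c2ccc(-c3ccc(-c4cccs4)s3)s2)s1`. The change bromo in place of azidomethyl on a saturated chain carbon, three bonds along the chain from an aromatic carbon puts bromo in place of azidomethyl on a saturated chain carbon, three bonds along the chain from an aromatic carbon. Among the measured compounds shown here, no measured step is available to size this change. The expected step in this assay is none beyond the scatter, with the limit of compound 2 at > 200000 nM as the only anchor. Compound 4 is expected at 200000 nM, with an estimated range of 80000 nM to 400000 nM.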

Compound 4, half-maximal cytotoxic concentration: > 200000 nM
Compound 4 gave a limit, no number (the forecaster's own chance of this, stated with the estimate: 70%); the middle value lies on the limit itself.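

No step can be read from compound 3 to compound 4. In this assay compound 4 gives > 200000 nM, a limit and not a number. The compounds shown leave open whether bromo in place of azidomethyl shifts this read-out at all.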